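A few compounds are considered here, and "the series" means these few. Any claim that something is new, unique, unknown or untested is made for them only; others in the source may bear on it.

Compound 1 `COc1ccc(-c2ccn(CCC(C)C)c(=O)c2C#N)cc1` gives 160% in a functional assay on CHO cells for positive allosteric modulation of metabotropic glutamate receptor 2 (Homo sapiens), read by scintillation counting and GTPgammaS binding, with a stated time of 30 min; on this read-out lower numbers stand for smaller maximal responses and higher numbers for larger maximal responses.
Compound 2 `CC(C)CCn1ccc(-c2ccc(OCC3CC3)cc2)c(C#N)c1=O` gives 192% in this assay.
Compound 3 `CNc1ccc(-c2ccn(CCC(C)C)c(=O)c2C#N)cc1` gives 186% in this assay.

Compound 3 stands second highest of the three. Its nearest neighbour is compound 2: the step of a number 6 percentage points lower from compound 2 to compound 3 (within the scatter) lies within the usual scatter, so the two cannot be ranked against each other. Its furthest neighbour is compound 1, and the step of a number 26 percentage points higher from compound 1 to compound 3 (beyond the scatter) is beyond the scatter.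

Compound 4 `Cc1ccc(Oc2ccc(-c3ccn(CCC(C)C)c(=O)c3C#N)cc2)c(C)n1` has not yet been measured. It differs from compound 3 in one place: (2,6-dimethylpyridin-3-yl)oxy in place of methylamino on an aromatic carbon. Among the compounds with values here, two measured steps bear on this position. Replacing methoxy by methylamino gave a number 26 percentage points higher from compound 1 to compound 3 (beyond the scatter), and replacing hydrogen on the saturated chain carbon bound to the ring oxygen by cyclopropyl gave a number 32 percentage points higher from compound 1 to compound 2 (beyond the scatter), so a larger group on this oxygen reached a higher maximal response than methoxy, and the bulky cyclopropylmethoxy compound 2 and the small methylamino compound 3 sit within scatter of each other. Within the data shown here, no measured compound carries an aromatic ring on this oxygen, so the new group has no direct precedent. On the evidence of compounds 2 and 3, the step of a number 1 percentage points lower from compound 3 to compound 4 (within the scatter) is expected to stay within the scatter. Compound 4 is estimated at 185%, within a range of 145% to 225%.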

Compound 4, largest response reached (Emax), in percent of the reference or control that the assay uses: 246%
The estimate for compound 4 lay 61 percentage points below the measured number; measured number above the stated range.
By their numbers in this assay, from the lowest: compound 1; then compounds 3 and 2 (each within the scatter of the next); then compound 4.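

Swapping the methylamino group for (2,6-dimethylpyridin-3-yl)oxy in this assay gave a number 60 percentage points higher from compound 3 to compound 4 (beyond the scatter), while on the same oxygen, 2,6-dimethylpyridin-3-yl in place of cyclopropylmethyl gave a number 54 percentage points higher from compound 2 to compound 4 (beyond the scatter) and in place of methyl gave a number 86 percentage points higher from compound 1 to compound 4 (beyond the scatter). The earlier compounds shown here showed only that this position could lift the maximal response above the level of the methoxy compound; compound 2 and compound 3 could not be ranked against each other, and this result shows that the position can go well past both of them when it carries an oxygen-linked six-membered aromatic ring with 1 hetero atom. Nothing available here explains why this group reaches the largest response of the four.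

The compounds shown do not separate the contributions of the ring, its nitrogen and its two methyl groups, which a plain phenoxy group or an unsubstituted pyridin-3-yloxy group could help to tell apart. From the compounds shown here alone, it also remains open whether the oxygen link itself matters, a question that an anilino group, with an amine nitrogen joining the two rings, would address.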